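Swapping hydroxymethyl for phenyl on compound 1

The source may hold more compounds than are shown below. What is called first, only, known or untested is meant among the compounds shown, and "the series" means these compounds.

In a functional assay on MCF7 cells (Homo sapiens) for inhibition, read by MTT assay, with a stated time of 72 h, tested at 50 uM (on this read-out higher numbers stand for more inhibition of growth at the one concentration tested and lower numbers for less inhibition of growth), compound 1 `C=CCc1cc(O)c(O)c(CN2CCC(CCO)CC2)c1` gives 33.3% as its result. Measured the same way, compound 3 `C=CCc1ccc(OCc2cn(-c3ccccc3CO)nn2)c(O)c1` gives 40.4% and cannot be told apart from compound 1, while compound 2 `C=CCc1ccc(OCc2cn(-c3ccc(OC)cc3)nn2)c(O)c1` at 57.2% stands clearly higher than compound 1.

The next compound to consider is compound 4 `C=CCc1cc(O)c(O)c(CN2CCC(Cc3ccccc3)CC2)c1`, which differs from compound 1 in one place. The change is phenyl in place of hydroxymethyl on a saturated chain carbon bound to a saturated ring carbon, counted as phenyl in place of hydroxymethyl on a saturated chain carbon bound to a saturated ring carbon and equally read as 2-hydroxyethyl to benzyl.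

Going by the values given here, only one measured step bears on this, and only loosely, since it stands on another core. With 2-(hydroxymethyl)phenyl in place of 4-methoxyphenyl on an aromatic nitrogen, the result is a number 16.8 percentage points lower from compound 2 to compound 3 (beyond the scatter) and so the compound gaining hydroxymethyl reads lower. Turned the other way round, that single step suggests a rise of similar size when hydroxymethyl leaves, which gives an estimated a number 16.7 percentage points higher from compound 1 to compound 4 (beyond the scatter) in this assay with wide uncertainty. Compound 4 is thus expected at 50% with a range of 32% to 72% as the estimate.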

Compound 4, percent growth inhibition at one concentration: 86.3%
Compound 4: middle estimate off by 36.3 percentage points, on the low side, outside the stated range (above it).
By their numbers in this assay, from the lowest: compounds 1 and 3 (each within the scatter of the next); then compound 2; then compound 4.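

Putting phenyl in place of hydroxymethyl in this assay gives a number 53 percentage points higher from compound 1 to compound 4 (beyond the scatter), a large step on the core of compound 1. This shows that the group carried on this saturated chain carbon bound to a saturated ring carbon can strongly change growth inhibition at the one concentration tested, and the step is much larger than a number 16.8 percentage points lower from compound 2 to compound 3 (beyond the scatter), which stands on another core. Nothing in the data shown accounts for the size of the step from 2-hydroxyethyl to benzyl.

This single change takes away a hydroxymethyl, with its hydrogen-bond donor and acceptor, and brings in a six-membered aromatic ring of carbon only, and the compounds shown cannot separate these two parts of the change. Going by these compounds, a plain carbon chain such as ethyl or propyl in the same place would help to separate them, while a phenyl bearing an amine or a carboxylic acid would show whether the ring tolerates further groups, and the response across a range of concentrations also remains open.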